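Returning to an aromatic ring on the amide nitrogen

The compounds below may be only part of what the source reports. "The series", "measured", "known", "first", "only" and "open" are said of these compounds alone.

Among the measured compounds shown here, compound 2 `COc1ccc(C(=O)NN2C(Cl)=NC=CC2Cl)cc1OC1CCCC1` gives the higher of the two numbers measured so far: in an assay on isolated protein for inhibition of phosphodiesterase 4A (Sus scrofa) (a lower number here means a stronger inhibitor, a higher number a weaker inhibitor), compound 2 gives 400 nM, whereas compound 1 `COc1ccc(C(=O)Nc2ccncc2Cl)cc1OC1CCCC1` gives 16 nM. For the measured compounds named here, the single measured step, a 25-fold higher number from compound 1 to compound 2 (1.40 log units; beyond the scatter), bears directly on compound 3 `COc1ccc(C(=O)Nc2c(C)nsc2C)cc1OC1CCCC1`, which differs from compound 2 by a group of 7 heavy atoms (5 carbon, 1 nitrogen, 1 sulfur; one five-membered aromatic ring with 2 hetero atoms) in place of a group of 8 heavy atoms (4 carbon, 2 nitrogen, 2 chlorine; one six-membered non-aromatic ring with 2 hetero atoms), on an amide-type nitrogen. That change brings back an aromatic ring on the amide nitrogen, as in compound 1, so a move back toward the lower number is expected. For compound 3 the estimated step is a 13-fold lower number from compound 2 to compound 3 (1.12 log units; beyond the scatter). Compound 3 is therefore expected to give about 30 nM in this assay, within 8 nM to 120 nM.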

Compound 3, half-maximal inhibitory concentration: 500 nM
The estimate for compound 3 lay 17-fold (1.22 log units) below the measured number; measured number above the stated range.
By their numbers in this assay, from the lowest: compound 1; then compounds 2 and 3 (each within the scatter of the next).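

An aromatic ring on the amide-type nitrogen is therefore not enough for a low number in this assay: 3,5-dimethyl-1,2-thiazol-4-yl in place of 3-chloropyridin-4-yl gives a large loss (a 31-fold higher number from compound 1 to compound 3 (1.49 log units; beyond the scatter)), and it does not separate from the non-aromatic ring (a 1.3-fold higher number from compound 2 to compound 3 (0.10 log units; within the scatter)). Among these compounds, only 3-chloropyridin-4-yl gives a low number at this position. Nothing available explains this result.

Which difference between these two aromatic groups carries the step remains open: ring size, the sulfur, the methyl groups or the chlorine. A plain pyridin-4-yl or a 3-methylpyridin-4-yl on the same nitrogen would help to separate these.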